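Swapping hydrogen for bromo on the benzyl ring

The compounds below may be only part of what the source reports. "The series", "measured", "known", "first", "only" and "open" are said of these compounds alone.

In a functional assay on HPAC cells (Homo sapiens) for inhibition, read by MTT assay, with a stated time of 72 h (on this read-out higher numbers stand for weaker inhibition of growth and lower numbers for stronger inhibition of growth), the measured compounds gave:
compound 1, `O=S(=O)(NCCCNCc1ccccc1Cl)c1cc(C(F)(F)F)cc(C(F)(F)F)c1`, 10000 nM;
compound 2, `O=S(=O)(NCCCNCc1ccc(Cl)c(C(F)(F)F)c1)c1cc(C(F)(F)F)cc(C(F)(F)F)c1`, 3000 nM;
compound 3, `O=S(=O)(NCCCNCc1ccccc1)c1cc(C(F)(F)F)cc(C(F)(F)F)c1`, 3200 nM.

Compound 3 thus stands second highest of the three numbers, close to compound 2 and well apart from compound 1. Compound 4, `O=S(=O)(NCCCNCc1ccc(Br)cc1)c1cc(C(F)(F)F)cc(C(F)(F)F)c1`, differs from compound 3 by bromo in place of hydrogen on an aromatic carbon. Within the data shown here, two measured steps bear on this: a 3.1-fold lower number from compound 1 to compound 3 (0.49 log units; beyond the scatter), and a 1.1-fold higher number from compound 2 to compound 3 (0.03 log units; within the scatter). A substituent on the benzyl ring away from the position changed in compound 1 therefore left the number essentially unchanged, so for the added bromo no step beyond the scatter is expected in this assay. The estimate for compound 4 is 3000 nM, with a range from 1500 nM to 6500 nM, which means an expected step of a 1.1-fold lower number from compound 3 to compound 4 (0.03 log units; within the scatter).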

Compound 4, concentration for 50% growth inhibition: 2900 nM
The estimate for compound 4 lay 1.0-fold (0.01 log units) above the measured number; measured number inside the range.
By their numbers in this assay, from the lowest: compounds 4, 2 and 3 (each within the scatter of the next); then compound 1.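

In this assay, bromo on the aromatic carbon para to a large group gives no change beyond the scatter (a 1.1-fold lower number from compound 3 to compound 4 (0.04 log units; within the scatter)), so this position accepts one bromine atom without a measurable shift. The 4-bromophenyl and 4-chloro-3-(trifluoromethyl)phenyl groups also read alike (a 1.0-fold lower number from compound 2 to compound 4 (0.01 log units; within the scatter)), while the 2-chlorophenyl compound remains apart (a 3.4-fold lower number from compound 1 to compound 4 (0.54 log units; beyond the scatter)). No measurement shown here explains these results. On these data alone, whether an amine or a carboxylic acid at this position would shift the number remains open. The effect of a longer chain in the shared core is also unknown.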